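Piperazin-1-yl replacement on compound 2: working notes

The source may report more compounds than this note shows. Statements on the series, on what has been measured and on what is new or still open speak of the compounds shown alone.

compound 1 `CCC(C)n1ncn(-c2ccc(N3CCN(c4ccc(OC[C@@H]5CO[C@@](CC)(c6ccc(Cl)cc6Cl)O5)cc4)CC3)cc2)c1=O`: 353 nM
compound 2 `CCC(C)n1ncn(-c2ccc(N3CCN(c4ccc(OC[C@@H]5CO[C@@](CN6CCNCC6)(c6ccc(Cl)cc6Cl)O5)cc4)CC3)cc2)c1=O`: 608 nM
compound 3 `CCC(C)n1ncn(-c2ccc(N3CCN(c4ccc(OC[C@@H]5CO[C@@](Cn6cnc(C(F)(F)F)n6)(c6ccc(Cl)cc6Cl)O5)cc4)CC3)cc2)c1=O`: 270 nM

All three values come from a functional assay on HUVEC cells (Homo sapiens), read by scintillation counting and thymidine incorporation, with a stated time of 24 h; a lower number here means a stronger inhibitor, a higher number a weaker inhibitor. For the measured compounds named here, compound 2 carries the highest number of the three, 608 nM, but it is clearly separated from only one neighbour. The two steps that reach it are a 1.7-fold higher number from compound 1 to compound 2 (0.24 log units; within the scatter) and a 2.3-fold lower number from compound 2 to compound 3 (0.35 log units; beyond the scatter).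

Compound 4 `CCC(C)n1ncn(-c2ccc(N3CCN(c4ccc(OC[C@@H]5CO[C@@](Cn6ccnc6-c6ccccc6)(c6ccc(Cl)cc6Cl)O5)cc4)CC3)cc2)c1=O` has not been measured. Its difference from compound 2 is 2-phenyl-1H-imidazol-1-yl in place of piperazin-1-yl on a saturated chain carbon bound to a saturated ring carbon. In words, 2-phenyl-1H-imidazol-1-yl stands in place of piperazin-1-yl on a saturated chain carbon bound to a saturated ring carbon.

Going by the values given here, the closest precedent is compound 3, which leaves the same place with a different entering group: a 2.3-fold lower number from compound 2 to compound 3 (0.35 log units; beyond the scatter). Among the compounds with values here, no measured compound carries the entering group of compound 4, so the precedent is indirect. A modest move to a lower number in this assay is expected, of about the size seen for compound 3. The step expected is a 2.0-fold lower number from compound 2 to compound 4 (0.31 log units; beyond the scatter). Compound 4 is estimated at 300 nM, with an expected range of 130 nM to 700 nM.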

Compound 4, half-maximal inhibitory concentration: 136 nM
The estimate for compound 4 lay 2.2-fold (0.34 log units) above the measured number; low and high end bracket the measured number.
By their numbers in this assay, from the lowest: compounds 4, 3, 1 and 2 (each within the scatter of the next, the first and the last beyond it).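

In this assay, for the compounds shown here, 2-phenyl-1H-imidazol-1-yl on a saturated chain carbon bound to a saturated ring carbon gives a 4.5-fold lower number from compound 2 to compound 4 (0.65 log units; beyond the scatter), and it is also the first group at this place to clear the scatter against the methyl of compound 1, with a 2.6-fold lower number from compound 1 to compound 4 (0.41 log units; beyond the scatter). Compound 3 had stayed within the scatter of compound 1, so the place can respond to the entering group against both reference compounds. Against the 3-(trifluoromethyl)-1H-1,2,4-triazol-1-yl group the new group is not separated, with a 2.0-fold lower number from compound 3 to compound 4 (0.30 log units; within the scatter), so no order can be set between these two. Nothing on hand accounts for these steps.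

As far as these compounds go, how much of the step belongs to the phenyl ring stays open, and a plain 1H-imidazol-1-yl at this place would address that. A morpholin-4-yl or a carboxylic acid here would show whether the weaker piperazin-1-yl result extends to other non-aromatic or charged groups.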